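Swapping Isopropylcarbonyl for Butylsulfonyl: What Happens to Exposure?

The source may report more compounds than this note shows. Statements on the series, on what has been measured and on what is new or still open speak of the compounds shown alone.

Measured compounds:
- compound 1 `O=C(Nc1ccc(C(F)(F)F)cc1)NC1CCN(C(=O)C2CC2)CC1`: 8750 ng.h/mL
- compound 2 `CC(C)C(=O)N1CCC(NC(=O)Nc2ccc(OC(F)(F)F)cc2)CC1`: 7280 ng.h/mL

Both numbers come from an ADME assay on the whole organism (plasma, strain Swiss Webster) for pharmacokinetics, with Mus musculus as the target, using cassette dosing, at a dose of 0.3 mg/kg by the oral route; on this read-out lower numbers stand for lower exposure and higher numbers for higher exposure at the dose given. An area under the curve sums how much compound reaches the plasma over time, so it gives a single measure of exposure after a dose. In this assay, compound 2 gives 7280 ng.h/mL and compound 1 gives 8750 ng.h/mL. These two values lie within the usual scatter of each other, so compound 2 cannot be separated from compound 1 on these data.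

Compound 3 `CCCCS(=O)(=O)N1CCC(NC(=O)Nc2ccc(OC(F)(F)F)cc2)CC1` has butylsulfonyl in place of isopropylcarbonyl on an amine nitrogen in a ring. Within the data shown here, no measured pair of compounds differs in just one place, and neither measured compound carries butylsulfonyl, so the data offer no direct guide to this change. The size of the step is therefore a cautious judgement, and the uncertainty is wide. The expected change is a drop beyond the usual scatter, estimated as a 2.9-fold lower number from compound 2 to compound 3 (0.46 log units; beyond the scatter). The estimated value for compound 3 is 2500 ng.h/mL, with an expected range from 600 ng.h/mL to 9000 ng.h/mL.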

Compound 3, area under the concentration-time curve in the Mus musculus assay: 93.2 ng.h/mL
The estimate for compound 3 lay 27-fold (1.43 log units) above the measured number; the whole stated range lies above it.
By their numbers in the Mus musculus assay, from the lowest: compound 3; then compounds 2 and 1 (each within the scatter of the next).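

At this position, on an amine nitrogen in a ring of a six-membered non-aromatic ring, the choice of group matters greatly for exposure: in the Mus musculus assay, butylsulfonyl in place of isopropylcarbonyl gives a 78-fold lower number from compound 2 to compound 3 (1.89 log units; beyond the scatter). Among these compounds, the earlier compounds offered no step at this position, so this is the first direct view of how sensitive it is. In a physicochemical assay for solubility, in phosphate buffer, at pH 7.4 (a lower number here means a less soluble compound, a higher number a more soluble compound), compound 2 gives 27 ug/mL and compound 3 gives 0.6 ug/mL. Part of the loss in exposure may arise because the same change also sharply lowers the number in the physicochemical assay: the measured solubility of compound 2, 27 ug/mL, and of compound 3, 0.6 ug/mL, a 45-fold lower number (1.65 log units; beyond the scatter)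

This single pair changes the carbonyl to a sulfonyl and alters the chain at the same time, so it cannot show which of the two drives the drop, or whether solubility accounts for all of it. The compounds shown leave open how a shorter group such as methylsulfonyl, or butylcarbonyl, which keeps the carbonyl and carries a straight chain, would behave, and whether a chain ending in an amine or a carboxylic acid would restore exposure.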